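The source may report more compounds than this note shows. Statements on the series, on what has been measured and on what is new or still open speak of the compounds shown alone.

Working notes on the series, measured in an ADME assay on KB cells (Homo sapiens) for cytotoxicity, read by MTT assay, with a stated time of 72 h; on this read-out lower numbers stand for stronger inhibition and higher numbers for weaker inhibition:

- compound 1 `COc1ccc(C2=C(c3cc(OC)c(OC)c(OC)c3)CC(O)C2=O)cc1[N+](=O)[O-]` gives > 100 ug/mL (a limit)
- compound 2 `COc1ccc(C2=C(c3cc(OC)c(OC)c(OC)c3)CC(O[SiH2]C(C)(C)C)C2=O)cc1[N+](=O)[O-]` gives > 100 ug/mL (a limit)

Within the data shown here, compound 1 stands only at a limit of the assay, not at a number, as does every value so far (the limit of > 100 ug/mL in this assay, at which 2 of the 2 values shown sit). Compound 3 `COc1ccc(C2=C(c3cc(OC)c(OC)c(OC)c3)CC(O)C2=O)cc1N` differs from compound 1 by amino in place of nitro on an aromatic carbon. Among the measured compounds shown here, the one measured step, a step that the two limits leave unreadable from compound 1 to compound 2, lies at another place, on an oxygen on a saturated carbon, and gives no size to carry over. In this assay the expected at least 5.0-fold lower number from compound 1 to compound 3 (0.69 log units; beyond the scatter) is therefore a loose estimate, in the direction of stronger inhibition. Compound 3 is estimated at 20 ug/mL, with an expected range of 0.3 ug/mL to 150 ug/mL.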

Compound 3, half-maximal inhibitory concentration: < 1 ug/mL
Compound 3: only a limit was reported; the forecaster's own chance of this, stated with the estimate: 35%; middle value at least 20-fold (1.30 log units) from the limit.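

In this assay, among these compounds, the aromatic carbon ortho to a methoxy group proves highly sensitive: amino in place of nitro gives an at least 100-fold lower number from compound 1 to compound 3 (2.00 log units; beyond the scatter) and is the first readable step, since the step on the oxygen cannot be read. Compound 3 stands at a limit, as does compound 1, so this step is a bound and not an exact size. From the compounds shown here alone, whether an acetamide or a hydroxyl on this carbon would keep the number of compound 3 stays open. Also open, going by these compounds, is whether the free hydroxyl on the saturated carbon still matters with amino present.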